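Ester aryl variation in a urotensin-2 receptor series

The source may hold more compounds than are shown below. What is called first, only, known or untested is meant among the compounds shown, and "the series" means these compounds.

Three esters of a shared core were measured in an assay on NIH3T3 cells with Urotensin-2 receptor (Homo sapiens) as the target; on this read-out higher numbers stand for an effect only at larger amounts of compound and lower numbers for an effect already at smaller amounts. Compound 1 `CCc1ccccc1C(=O)OC(CCN(C)C)c1ccc(Cl)cc1` gives 1290 nM and stands second highest among the three numbers. Compound 2 `COc1cccc(C(=O)OC(CCN(C)C)c2ccc(Cl)cc2)c1C` gives 1950 nM, which lies within the scatter of the value of compound 1, so no order between the two can be stated. Compound 3 `Cc1cc(C)c(C(=O)OC(CCN(C)C)c2ccc(Cl)cc2)cc1C` gives 468 nM, a lower number that sits beyond the scatter from compound 1.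

Compound 4 `Cc1cc(Br)ccc1C(=O)OC(CCN(C)C)c1ccc(Cl)cc1` has not yet been measured. It differs from compound 1 in one place: 4-bromo-2-methylphenyl in place of 2-ethylphenyl on a carbonyl carbon. Going by the values given here, no measured pair shows this change, so its size is not known from the data. Compound 4 is expected to give a lower number than compound 1, because compound 3 with 468 nM shows that a differently substituted aryl ring at this place can lower the number well beyond the scatter, though the step is estimated to be modest, as a 1.8-fold lower number from compound 1 to compound 4 (0.27 log units; within the scatter). Compound 4 is therefore estimated at 700 nM, with a range from 250 nM to 2000 nM.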

Compound 4, half-maximal effective concentration: 1070 nM
Estimate against measurement, compound 4: 1.5-fold (0.18 log units) below, within the range that was stated.
By their numbers in this assay, from the lowest: compound 3; then compounds 4, 1 and 2 (each within the scatter of the next).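

In this assay, going by these compounds alone, the exchange of 2-ethylphenyl for 4-bromo-2-methylphenyl on a carbonyl carbon gives a 1.2-fold lower number from compound 1 to compound 4 (0.08 log units; within the scatter), the first step between two measured compounds that differ in one place. It shows that this place can take a bromine and a methyl in place of an ethyl without a change that can be told from the scatter, so a new substitution on the aryl ring does not by itself shift the number. Nothing available explains this result.

The step changes two things at once, so the shares of the bromine and of the methyl in place of the ethyl stay unresolved. Also open, as far as these compounds go, is whether an aryl ring carrying an amine or a carboxylic acid at this place would stay close to compound 1 or reach a number like that of compound 3, 468 nM.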